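Trifluoromethyl to chloro: an estimate for compound 3

The source may report more compounds than this note shows. Statements on the series, on what has been measured and on what is new or still open speak of the compounds shown alone.

Compound 1 `COc1cc(NC(C)CCCNC(=O)NNC(=O)Nc2ccc(Br)cc2)c2ncccc2c1`: 231000 nM
Compound 2 `COc1cc(NC(C)CCCNC(=O)NNC(=O)Nc2cccc(C(F)(F)F)c2)c2ncccc2c1`: 5600 nM

Both values come from a functional assay on MIA PaCa-2 cells (Homo sapiens) for inhibition, read by MTT assay, with a stated time of 72 h; on this read-out higher numbers stand for weaker inhibition and lower numbers for stronger inhibition. Of the two compounds measured, compound 2 has the lower number, 5600 nM, and so shows the stronger inhibition, with a gap to compound 1 that lies beyond the scatter.

Compound 3 `COc1cc(NC(C)CCCNC(=O)NNC(=O)Nc2cccc(Cl)c2)c2ncccc2c1` differs from compound 2 in one place, with chloro in place of trifluoromethyl on an aromatic carbon. For the measured compounds named here, only one measured step bears on this change: a 41-fold lower number from compound 1 to compound 2 (1.62 log units; beyond the scatter). That large step replaced 4-bromophenyl with 3-(trifluoromethyl)phenyl, so the group and its place changed together, and the data cannot separate the two. Going by the values given here, no measured step swaps the group alone at this place. The step does show that this end of the molecule can move the number strongly in this assay, so a modest rise in the number is expected rather than a large one. The expected change is a 1.8-fold higher number from compound 2 to compound 3 (0.25 log units; within the scatter), near the edge of the scatter. For compound 3 the estimated value is 10000 nM, with an expected range of 3500 nM to 40000 nM.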

Compound 3, half-maximal inhibitory concentration: 74000 nM
Compound 3: the middle estimate sits 7.4-fold (0.87 log units) below what was measured; measured number above the stated range.
By their numbers in this assay, from the lowest: compound 2; then compound 3; then compound 1.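

With its place on the ring held fixed, the group alone now has a reading of its own in this assay: the change from trifluoromethyl to chloro gives a 13-fold higher number from compound 2 to compound 3 (1.12 log units; beyond the scatter) and so moves the number strongly without any change of place, which the earlier pair could not show. The second new step, with 3-chlorophenyl in place of 4-bromophenyl, is a 3.1-fold lower number from compound 1 to compound 3 (0.49 log units; beyond the scatter) and is much smaller than the step from 4-bromophenyl to 3-(trifluoromethyl)phenyl, so among these three compounds the low number of compound 2 goes with trifluoromethyl and is not matched by chloro at the same place. No measurement at hand accounts for the size of either step.

From the compounds shown here alone, in the step from compound 1 to compound 3, the halogen and its place still change together, so the share of each remains unknown. The compounds shown also leave open how an amine, a nitrile or a methoxy group at this same place would compare with chloro and trifluoromethyl.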